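Thiophene for methoxyphenyl in a sulfonamide pyrazoline series

The source may hold more compounds than are shown below. What is called first, only, known or untested is meant among the compounds shown, and "the series" means these compounds.

Of the compounds shown here, three have been tested in a functional assay on the whole organism for inhibition, with Rattus norvegicus as the target, read by paw edema, with a stated time of 3 h, at a dose of 50 mg/kg by the oral route; a higher number here means more inhibition at the dose given (going by the name of the read-out), a lower number less inhibition. Compound 1 `CS(=O)(=O)c1ccc(C2=NN(c3ccc(C(=O)O)cc3)C(c3ccc(Cl)cc3)C2)cc1` gives 50.4%. Compound 2 `CS(=O)(=O)c1ccc(C2=NN(c3ccc(C(=O)O)cc3)C(c3cccs3)C2)cc1` gives 35.6%. Compound 3 `COc1cccc(C2CC(c3ccc(S(C)(=O)=O)cc3)=NN2c2ccc(S(N)(=O)=O)cc2)c1` gives 38.3%. On these numbers compound 3 stands second of the three: its nearest neighbour is compound 2, which lies within the scatter of it, and the furthest is compound 1, whose higher number lies beyond the scatter.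

Compound 4 `CS(=O)(=O)c1ccc(C2=NN(c3ccc(S(N)(=O)=O)cc3)C(c3cccs3)C2)cc1` has not yet been measured. It differs from compound 3 in one place: thiophen-2-yl in place of 3-methoxyphenyl on a saturated ring carbon.

For the measured compounds named here, one measured step bears on this change. The step of a number 14.8 percentage points lower from compound 1 to compound 2 (beyond the scatter) put thiophen-2-yl on the same saturated ring carbon, although there it replaced 4-chlorophenyl and the compounds carried a carboxylic acid rather than a sulfamoyl group. The group leaving here is different, so the step is only a rough guide, but it points downward and beyond the scatter.

For compound 4 a modest drop from compound 3 is therefore expected, a number 9.3 percentage points lower from compound 3 to compound 4 (within the scatter), with the estimate 29% and a likely range from 17% to 41%.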

Compound 4, a percentage reported as inhibition, in the whole organism at one dose (the size of the read-out at that dose, not a potency): 36.4%
Estimate against measurement, compound 4: 7.4 percentage points below; the measured number falls inside the stated range.
By their numbers in this assay, from the lowest: compounds 2, 4 and 3 (each within the scatter of the next); then compound 1.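

In this assay the change from 3-methoxyphenyl to thiophen-2-yl on the saturated ring carbon gives a number 1.9 percentage points lower from compound 3 to compound 4 (within the scatter) and so stays inside the usual scatter, which means that the larger step seen earlier, a number 14.8 percentage points lower from compound 1 to compound 2 (beyond the scatter) with 4-chlorophenyl as the group leaving and carboxy on the aromatic carbon, does not hold for every swap to thiophen-2-yl at this position. The second new step, with sulfamoyl in place of carboxy on an aromatic carbon, gives a number 0.8 percentage points higher from compound 2 to compound 4 (within the scatter) and shows that, with thiophen-2-yl on the saturated ring carbon, this exchange shifts the paw-swelling result by no more than the scatter. Nothing measured here offers a reason for either result.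

The compounds shown leave open how 4-chlorophenyl behaves alongside sulfamoyl, a pairing that would show whether its advantage over thiophen-2-yl depends on carboxy being present. They also leave open whether a non-aromatic group on the saturated ring carbon, such as a simple amine or a short alkyl chain, would keep the inhibition seen with the aromatic rings.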